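This account rests on a few compounds, and the source may have more. Where it says the series, first, only, none or still open, it means among the compounds named here.

Compound 1 `C/C(=N\NC(=O)/C(C#N)=C/c1ccc(O)cc1)c1c(O)c2ccc(O)cc2oc1=O`: 7320 nM
Compound 2 `C/C(=N\NC(=O)/C(C#N)=C/c1cccc([N+](=O)[O-])c1)c1c(O)c2ccc(O)cc2oc1=O`: 16400 nM
Compound 3 `C/C(=N\NC(=O)/C(C#N)=C/c1ccc([N+](=O)[O-])cc1)c1c(O)c2ccc(O)cc2oc1=O`: 8200 nM

In a functional assay on MCF7 cells (Homo sapiens) for cytotoxicity, read by MTT assay, with a stated time of 24 h (on this read-out lower numbers stand for stronger inhibition and higher numbers for weaker inhibition), compound 3 gives 8200 nM, second highest of the three numbers, though within the scatter of both others: a 1.1-fold higher number from compound 1 to compound 3 (0.05 log units; within the scatter) and a 2.0-fold lower number from compound 2 to compound 3 (0.30 log units; within the scatter). Compound 4 `C/C(=N\NC(=O)/C(C#N)=C/c1ccccc1[N+](=O)[O-])c1c(O)c2ccc(O)cc2oc1=O` carries one change, 2-nitrophenyl in place of 4-nitrophenyl on a double-bonded chain carbon bound to a double-bonded chain carbon. The closest measured change, swapping 3-nitrophenyl for 4-nitrophenyl, gave a 2.0-fold lower number from compound 2 to compound 3 (0.30 log units; within the scatter). The larger 2.2-fold higher number from compound 1 to compound 2 (0.35 log units; beyond the scatter) was only modest. Among the measured compounds shown here, no step clearly beyond the scatter is therefore expected in this assay, and the direction remains uncertain. The estimate is a 1.3-fold higher number from compound 3 to compound 4 (0.13 log units; within the scatter). Compound 4 is expected at 11000 nM, with an estimated range of 5000 nM to 22000 nM.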

Compound 4, half-maximal inhibitory concentration: 9180 nM
Beside the measured number, compound 4's estimate is 1.2-fold (0.08 log units) above it, and the stated range covers the measured number.
By their numbers in this assay, from the lowest: compounds 1, 3, 4 and 2 (each within the scatter of the next, the first and the last beyond it).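

In this assay, 2-nitrophenyl in place of the other two nitrophenyl groups stays within the scatter of both (a 1.1-fold higher number from compound 3 to compound 4 (0.05 log units; within the scatter); a 1.8-fold lower number from compound 2 to compound 4 (0.25 log units; within the scatter)), so all three nitrophenyl compounds now read alike on this double-bonded chain carbon. Unlike compound 2, compound 4 also stays within the scatter of the 4-hydroxyphenyl compound (a 1.3-fold higher number from compound 1 to compound 4 (0.10 log units; within the scatter)). No evidence bears on this result. On these data alone, whether an amine or a carboxylic acid on the phenyl ring in this place would give a step beyond the scatter remains open.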